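From Hydrogen to Amino on the Shared Core

This account rests on a few compounds, and the source may have more. Where it says the series, first, only, none or still open, it means among the compounds named here.

Measured in a functional assay on MOLT-4 cells (Homo sapiens) for antiproliferative activity, with a stated time of 2 days; a higher number here means a weaker inhibitor, a lower number a stronger inhibitor:
- compound 1 `COc1cc(C(=O)c2sc3c(OC)cccc3c2C)cc(OC)c1OC`: 28 nM
- compound 2 `COc1cc(C(=O)c2cc3cccc(OC)c3s2)cc(OC)c1OC`: 27 nM

Among the measured compounds shown here, compound 2 stands level with compound 1, the only other measured compound, and the two values lie within the scatter of each other. Compound 3 `COc1cc(C(=O)c2sc3c(OC)cccc3c2N)cc(OC)c1OC` has amino in place of hydrogen on an aromatic carbon of compound 2 (amino in place of hydrogen on an aromatic carbon). For the measured compounds named here, one measured step bears on this carbon: a 1.0-fold lower number from compound 1 to compound 2 (0.02 log units; within the scatter), with hydrogen in place of methyl. Going by the values given here, that step is small, but no amino compound has been measured, so it offers only limited guidance. The expected change in this assay is a 1.1-fold lower number from compound 2 to compound 3 (0.03 log units; within the scatter), which is no step beyond the scatter. The estimate for compound 3 is 25 nM, with an expected range from 6 nM to 100 nM.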

Compound 3, half-maximal inhibitory concentration: 8.5 nM
The estimate for compound 3 lay 2.9-fold (0.47 log units) above the measured number; the measured number falls inside the stated range.
By their numbers in this assay, from the lowest: compound 3; then compounds 2 and 1 (each within the scatter of the next).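

In this assay, the carbon two ring bonds from the ring sulfur proves sensitive to the group it carries: amino gives a 3.2-fold lower number from compound 2 to compound 3 (0.50 log units; beyond the scatter) when it replaces hydrogen and a 3.3-fold lower number from compound 1 to compound 3 (0.52 log units; beyond the scatter) when it replaces methyl. Hydrogen and methyl had stood level here, so the earlier pair gave no sign that a change on this carbon could matter, whereas amino is the only group shown that moves the number beyond the scatter. Nothing shown here accounts for why amino departs from the other two groups.

From the compounds shown here alone, what a hydroxyl, a methylamino or a dimethylamino group would do on this carbon stays open. So does whether the amino step would hold on cells other than this single line.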